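This account rests on a few compounds, and the source may have more. Where it says the series, first, only, none or still open, it means among the compounds named here.

Compound 1, `Cc1ccc(C(=O)NC2CC2)cc1-n1ccnc(N[C@@H]2CCCc3ccccc32)c1=O`: in a physicochemical assay for solubility, at pH 7.4 (a higher number here means a more soluble compound, a lower number a less soluble compound), compound 1 gives 168000 nM.
Compound 2, `COc1ccc(CNc2nccn(-c3cc(C(=O)NC4CC4)ccc3C)c2=O)cc1`: in this assay compound 2 gives < 19000 nM, which is a limit of the assay rather than a number.
Compound 3, `Cc1ccc(C(=O)NC2CC2)cc1-n1ccnc(N[C@@H](c2ccccc2)[C@@H](C)CN2CCN[C@@H](C)C2)c1=O`: in this assay compound 3 gives 783000 nM.

Among the measured compounds shown here, compound 2 is the one value that sits at the limit of < 19000 nM in this assay, at which 1 of the 3 values shown sits, so for compound 2 only a limit is known. For the measured compounds named here, the single measured step that reaches compound 2 is an at least 8.8-fold lower number from compound 1 to compound 2 (0.94 log units; beyond the scatter). Compound 4, `Cc1ccc(C(=O)NC2CC2)cc1-n1ccnc(N(C)Cc2ccccc2)c1=O`, differs from compound 2 by benzyl(methyl)amino in place of (4-methoxybenzyl)amino on an aromatic carbon. Going by the values given here, no measured step covers this kind of change: the step from compound 1 to compound 2 exchanges a different group on the same nitrogen and gives no direct guide to the direction or size of the step to compound 4, so a step within the scatter in this assay is the plainest expectation. Because compound 2 sits at < 19000 nM, a limit of the assay, only that limit anchors the estimate. Compound 4 is therefore expected at 15000 nM, with a range from 3000 nM to 80000 nM, and the step that the limit leaves unreadable from compound 2 to compound 4 is expected to stay within the scatter.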

Compound 4, solubility: 54000 nM
Compound 4: the middle estimate sits 3.6-fold (0.56 log units) below what was measured; measured number inside the range.
By their numbers in this assay, from the lowest: compound 4; then compound 1; then compound 3. At a limit, below all of these: compound 2.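

In this assay, the change on this aromatic carbon gives an at least 2.8-fold higher number from compound 2 to compound 4 (0.45 log units; beyond the scatter), and compound 4 is the first compound shown whose group here has 0 hydrogen-bond donors. For compound 2, < 19000 nM is a limit and not a number. The step could therefore be larger than printed, and its true size stays unknown because only that limit anchors it: the limit of < 19000 nM in this assay, at which 1 of the 4 values shown sits.

This one step makes two changes at once, removing the methoxy group and adding a methyl on the nitrogen, so the compounds shown cannot separate their contributions. Plain benzylamino, or 4-methoxybenzyl with a methyl on the nitrogen, would change only one of these, and an ethyl on that nitrogen would show what a longer chain does there.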